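A few compounds are considered here, and "the series" means these few. Any claim that something is new, unique, unknown or untested is made for them only; others in the source may bear on it.

Of the compounds shown here, three of one shared core have been tested in a functional assay on MDA-MB-231 cells (Homo sapiens) for cytotoxicity, read by MTT assay, with a stated time of 72 h; a lower number here means a stronger inhibitor, a higher number a weaker inhibitor. Compound 1, with the structure `CN(C)CCCNc1nc(-c2ccc(NC(=O)Nc3ccccc3F)cc2)nc2ccsc12`, gives 660 nM. Compound 2, with the structure `CN(C)CCNc1nc(-c2ccc(NC(=O)Nc3ccc(F)cc3)cc2)nc2ccsc12`, gives 540 nM. Compound 3, with the structure `CN(C)CCNc1nc(-c2ccc(NC(=O)Nc3ccccc3F)cc2)nc2ccsc12`, gives 600 nM. Among these three numbers compound 3 stands second highest, but its neighbours lie close on either side: the step of a 1.1-fold lower number from compound 1 to compound 3 (0.04 log units; within the scatter) and the step of a 1.1-fold higher number from compound 2 to compound 3 (0.05 log units; within the scatter) both stay inside the scatter, so the three compounds cannot be told apart on potency.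

Compound 4, with the structure `CCN(CC)CCNc1nc(-c2ccc(NC(=O)Nc3ccccc3F)cc2)nc2ccsc12`, has not yet been tested. It differs from compound 3 in one place: diethylamino in place of dimethylamino on a saturated chain carbon, two bonds along the chain from a nitrogen on an aromatic ring. Going by the values given here, the only measured step that touches this part of the molecule is a 1.1-fold lower number from compound 1 to compound 3 (0.04 log units; within the scatter), where the chain between the two nitrogens was shortened and the number hardly moved. Among the compounds with values here, no measured pair shows the dimethylamino to diethylamino exchange itself, so the expectation rests on that neighbouring step alone. Compound 4 is therefore expected to sit near compound 3, with a step of a 1.0-fold higher number from compound 3 to compound 4 (0.01 log units; within the scatter) that stays within the scatter. The estimate for compound 4 in this assay is 620 nM, with a range from 300 nM to 1300 nM.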

Compound 4, half-maximal inhibitory concentration: 580 nM
Beside the measured number, compound 4's estimate is 1.1-fold (0.03 log units) above it; the measured number falls inside the stated range.
By their numbers in this assay, from the lowest: compounds 2, 4, 3 and 1 (each within the scatter of the next).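

In this assay, the exchange of dimethylamino for diethylamino on the saturated chain carbon can now be read directly: the step is a 1.0-fold lower number from compound 3 to compound 4 (0.01 log units; within the scatter). Going by these compounds alone, the entering group has 5 heavy atoms where the leaving group has 3, so this position accepts a larger amine end without any difference that can be told from ordinary assay noise, something the earlier compounds, which all carried dimethylamino, could not show. The step of a 1.1-fold lower number from compound 1 to compound 4 (0.06 log units; within the scatter) points the same way, since compounds with different amine ends and different spacing between the two nitrogens remain indistinguishable in this cell assay, and no supporting measurement is available to explain why the number stays so flat.

On these data alone, all the amine ends seen so far are open-chain dialkylamino groups, so it remains open whether a ring amine such as morpholine or piperidine, or a carboxylic acid in the same place, would also leave the number where it is. As far as these compounds go, a longer chain, or a chain ending in a primary amine, is equally open, and these compounds do not show how far this flatness extends.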